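Dichlorophenyl phosphate ester of an azidothymidine nucleotide

The source may report more compounds than this note shows. Statements on the series, on what has been measured and on what is new or still open speak of the compounds shown alone.

The measured compounds are:
compound 1, `O=c1ccn([C@H]2CC[C@@H](COP(=O)(O)Oc3ccncc3)O2)c(=O)[nH]1`, 23.6 h;
compound 2, `Cc1cn([C@H]2C[C@H](N=[N+]=[N-])[C@@H](COP(=O)(O)Oc3ccccc3)O2)c(=O)[nH]c1=O`, 9.47 h;
compound 3, `O=c1ccn([C@H]2CC[C@@H](COP(=O)(O)Oc3cccnc3)O2)c(=O)[nH]1`, 50.2 h.

In a physicochemical assay for metabolic stability, read by HPLC (on this read-out lower numbers stand for a shorter-lived compound and higher numbers for a longer-lived compound), compound 2 stands lowest of the three numbers. Its nearest neighbour is compound 1, and the furthest is compound 3; both gaps lie beyond the scatter. Going by the values given here, the only step between measured compounds that differ in one place is a 2.1-fold higher number from compound 1 to compound 3 (0.33 log units; beyond the scatter), and it concerns a pyridinyl ring on the oxygen.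

Compound 4, `Cc1cn([C@H]2C[C@H](N=[N+]=[N-])[C@@H](COP(=O)(O)Oc3ccc(Cl)cc3Cl)O2)c(=O)[nH]c1=O`, is not yet measured. It differs from compound 2 by 2,4-dichlorophenyl in place of phenyl on an oxygen. Among the compounds with values here, no measured step bears directly on this change: the one step in hand swaps the position of the nitrogen within a pyridinyl, whereas here two chlorines enter a phenyl. The step from compound 1 to compound 3 was modest, so a change of a similar order is plausible, but the data give no direction. Compound 4 is therefore expected near compound 2, with an estimated step of a 1.4-fold lower number from compound 2 to compound 4 (0.13 log units; within the scatter) and an estimated value of 7 h, between 2.5 h and 20 h.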

Compound 4, half-life: 3.03 h
For compound 4 the middle estimate is 2.3-fold (0.36 log units) above the measured one, within the range that was stated.
By their numbers in this assay, from the lowest: compound 4; then compound 2; then compound 1; then compound 3.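

In this assay, 2,4-dichlorophenyl in place of phenyl on the oxygen bound to phosphorus gives a 3.1-fold lower number from compound 2 to compound 4 (0.49 log units; beyond the scatter), which shows that the read-out at this position responds to a change on a ring of carbon only. Going by these compounds alone, until now, the only one-place step was a 2.1-fold higher number from compound 1 to compound 3 (0.33 log units; beyond the scatter), which moved a nitrogen within a pyridinyl ring on another core and gave no direction for chlorines entering a phenyl ring; this step runs downward. No measurement shown here accounts for the size or direction of the new step.

The two chlorines enter together, so the compounds shown leave open whether a single chlorine on the phenyl ring would give part of the step or all of it. They also leave open how a methoxy group on that ring, or a pyridin-3-yl in its place, would read on the core of compound 2.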